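The source may hold more compounds than are shown below. What is called first, only, known or untested is meant among the compounds shown, and "the series" means these compounds.

In a functional assay on HeLa cells (Homo sapiens) for inhibition, read by MTT assay, with a stated time of 48 h (on this read-out lower numbers stand for stronger inhibition of growth and higher numbers for weaker inhibition of growth), compound 1 `Cn1cc(C2CC(c3ccccc3)=NN2C(=O)c2cccnc2)c2ccccc21` gives > 10000 nM, and this value is a limit of the assay, not a number. For the measured compounds named here, compound 2 `Cn1cc(C2CC(c3ccccc3)=NN2C(=O)c2cccnc2)c2cc(Br)ccc21`, which carries bromo in place of hydrogen on an aromatic carbon, gives 1730 nM, the only actual number so far. Going by the values given here, the single measured step is an at least 5.7-fold lower number from compound 1 to compound 2 (0.76 log units; beyond the scatter).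

Compound 3 `COc1ccc(C2=NN(C(=O)c3cccnc3)C(c3cn(C)c4ccc(Br)cc34)C2)cc1OC` keeps the bromo of compound 2 and changes one place: 3,4-dimethoxyphenyl in place of phenyl on a carbon with a double bond to nitrogen. It has 3,4-dimethoxyphenyl in place of phenyl on a carbon with a double bond to nitrogen. The step to compound 2 was made elsewhere on the core, so it shows that this assay can respond to a single substitution but gives no size or direction for this one. Among the compounds with values here, no measured step touches this place. Only a small move towards a lower number is therefore expected, and it may not clear the scatter. The expected change is a 1.7-fold lower number from compound 2 to compound 3 (0.24 log units; within the scatter). For compound 3 the estimated value is 1000 nM, with an expected range from 250 nM to 4000 nM.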

Compound 3, concentration for 50% growth inhibition: 2090 nM
For compound 3 the middle estimate is 2.1-fold (0.32 log units) below the measured one; the range from low to high includes it.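

In this assay, for the compounds shown here, 3,4-dimethoxyphenyl in place of phenyl gives a 1.2-fold higher number from compound 2 to compound 3 (0.08 log units; within the scatter), the first reading at this place on a carbon with a double bond to nitrogen, and it does not clear the scatter. The entering group has 10 heavy atoms against 6 and 2 hydrogen-bond acceptors against 0, yet within this one pair those additions leave the read-out inside the scatter, so the place accepts this particular substitution with no measurable consequence. The step of an at least 5.7-fold lower number from compound 1 to compound 2 (0.76 log units; beyond the scatter) thus remains the only one shown that lies beyond the scatter, and nothing at hand bears on why the new step is so small.

As far as these compounds go, whether the same place would stay this flat with a different kind of group, such as an amine, a carboxylic acid or a longer alkyl chain on the phenyl, remains open. From the compounds shown here alone, it is also open whether 3,4-dimethoxyphenyl would behave the same way on the core of compound 1, without the bromo, so the two places cannot yet be said to act independently.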